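The source may hold more compounds than are shown below. What is called first, only, known or untested is meant among the compounds shown, and "the series" means these compounds.

Three compounds that share one core, and a fourth not yet tested, were compared in an ADME assay on cells (Splenocyte, Mus musculus, strain BALB/c) for cytotoxicity, read by CCK-8 assay, with a stated time of 48 h; on this read-out higher numbers stand for lower toxicity in this test and lower numbers for higher toxicity in this test. Compound 1 `COc1cccc(-c2nc(Cc3c[nH]c4ccccc34)no2)c1` gives 18400 nM in this assay. Compound 2 `COc1ccc(-c2nc(Cc3c[nH]c4ccccc34)no2)cc1` is built from the same atoms joined differently; the difference between the two cores is not broken down here. For compound 2 the result in this assay is a limit of the assay, > 50000 nM. Compound 3 `COc1ccc(-c2nc(Cc3c[nH]c4ccccc34)no2)c(OC)c1` gives 9300 nM in this assay. The change from compound 2 to compound 3 is methoxy in place of hydrogen on an aromatic carbon and it made an at least 5.3-fold lower number from compound 2 to compound 3 (0.73 log units; beyond the scatter). That step is stated as a bound because the value of compound 2 sits at the limit of > 50000 nM in this assay, at which 1 of the 3 values shown sits. The values of compound 1 and compound 3 lie within the usual scatter of each other.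

Compound 4 `COc1cc(OC)cc(-c2nc(Cc3c[nH]c4ccccc34)no2)c1` awaits measurement in this assay. It differs from compound 1 by methoxy in place of hydrogen on an aromatic carbon. This is the same kind of change as from compound 2 to compound 3, but not the same: there the entering methoxy sits ortho to a large group, here it sits meta to a large group, while in both cases it is meta to a methoxy group. The step expected here is a 1.8-fold lower number from compound 1 to compound 4 (0.26 log units; within the scatter), set beside the measured at least 5.3-fold lower number from compound 2 to compound 3 (0.73 log units; beyond the scatter), resting on the fact that a second methoxy entering the ring left compound 3 at 9300 nM. Compound 4 is therefore expected to give about 10000 nM in this assay, with a likely range from 4000 nM to 25000 nM.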

Compound 4, half-maximal cytotoxic concentration: > 50000 nM
Compound 4 was reported as a limit (the forecaster's own chance of this, stated with the estimate: 10%); middle value at least 5.0-fold (0.69 log units) from the limit.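

In this assay, methoxy in place of hydrogen on an aromatic carbon gave an at least 2.7-fold higher number from compound 1 to compound 4 (0.43 log units; beyond the scatter), which means lower toxicity in this test after the change. The same kind of change went the opposite way on the other core, so its effect on one of these cores could not be used to predict its effect on the other, and the gap between the two steps is too large to be ordinary scatter: the same change on two cores in this assay, an at least 5.3-fold lower number (0.73 log units; beyond the scatter) from compound 2 to compound 3 and an at least 2.7-fold higher number (0.43 log units; beyond the scatter) from compound 1 to compound 4, at least 14-fold (1.16 log units) apart, beyond the scatter of two such steps. Neither step has an exact size, since the results for compound 2 and compound 4 are limits of the assay, and the comparison shows neither why the direction differs nor how any further core would respond: the limit of > 50000 nM in this assay, at which 2 of the 4 values shown sit.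

The compounds shown leave open whether a different group on the same aromatic carbon, such as an ethoxy group, an amine or a carboxylic acid, would follow compound 3 or compound 4 in direction. They also leave open where the true values of compound 2 and compound 4 lie, and a wider range of test concentrations would be needed to settle how large the two steps really are.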